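Two Measured Analogues and a Methoxyphenyl Variant

The source may report more compounds than this note shows. Statements on the series, on what has been measured and on what is new or still open speak of the compounds shown alone.

Compound 1 `COc1ccc(/C=C2/SC(NN3Cc4ccccc4N=C3c3ccccc3)=NC2=O)cc1OC`: 1000 nM
Compound 2 `O=C1N=C(NN2Cc3ccccc3N=C2c2ccccc2)S/C1=C/c1ccc(O)cc1O`: 7490 nM

In a functional assay on MCF7 cells (Homo sapiens) for cytotoxicity, read by MTT assay, with a stated time of 4 h (on this read-out lower numbers stand for stronger inhibition and higher numbers for weaker inhibition), compound 2 holds the higher number of the two, set apart from compound 1 by the step of a 7.5-fold higher number from compound 1 to compound 2 (0.87 log units; beyond the scatter). Compound 3 `COc1ccc(/C=C2/SC(NN3Cc4ccccc4N=C3c3ccccc3)=NC2=O)cc1` differs from compound 2 in one place: 4-methoxyphenyl in place of 2,4-dihydroxyphenyl on a double-bonded chain carbon bound to a double-bonded ring carbon. For the measured compounds named here, the one step that bears on this, a 7.5-fold higher number from compound 1 to compound 2 (0.87 log units; beyond the scatter), raised the number when the dihydroxyphenyl came in; a return to a methoxy-bearing ring is therefore expected to lower it again. Compound 3 is estimated at 1500 nM, between 500 nM and 5000 nM, which means an expected step of a 5.0-fold lower number from compound 2 to compound 3 (0.70 log units; beyond the scatter).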

Compound 3, half-maximal inhibitory concentration: 3760 nM
Beside the measured number, compound 3's estimate is 2.5-fold (0.40 log units) below it; the range from low to high includes it.
By their numbers in this assay, from the lowest: compound 1; then compounds 3 and 2 (each within the scatter of the next).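

On the double-bonded chain carbon bound to a double-bonded ring carbon, 4-methoxyphenyl in place of 2,4-dihydroxyphenyl gives a 2.0-fold lower number from compound 2 to compound 3 (0.30 log units; within the scatter) in this assay and so does not separate these two rings. Hydrogen in place of methoxy on an aromatic carbon gives a 3.8-fold higher number from compound 1 to compound 3 (0.58 log units; beyond the scatter) and shows that this single group separates compound 3 from compound 1. Of the three rings, only the 3,4-dimethoxyphenyl of compound 1 stands apart from both others. From the compounds shown here alone, whether an amine or a carboxylic acid on this ring would fall nearer compound 1 or compound 3 remains open. No evidence is available to explain either step.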